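A few compounds are considered here, and "the series" means these few. Any claim that something is new, unique, unknown or untested is made for them only; others in the source may bear on it.

Compound 1 (`O=C(NCc1cc(Cl)ccc1-n1cnnn1)[C@@H]1CC=NN1C(=O)[C@H](O)Cc1ccccc1`) gives 11 10^-6 cm/s
Compound 2 (`CCCC[C@@H](O)C(=O)N1C[C@H]2C[C@H]2[C@H]1C(=O)NCc1cc(Cl)ccc1-n1cnnn1`) gives 33 10^-6 cm/s
Compound 3 (`CCCC[C@@H](O)C(=O)N1N=CC[C@H]1C(=O)NCc1cc(Cl)ccc1-n1cnnn1`) gives 9.8 10^-6 cm/s

In an ADME assay on Caco-2 cells (Homo sapiens) for permeability, read by LC-MS, in the apical to basolateral direction, with a stated time of 60 min, at pH 6.5 (on this read-out lower numbers stand for lower permeability and higher numbers for higher permeability), compound 2 stands highest of the three, beyond the scatter of both others. Compound 4 (`O=C(NCc1cc(Cl)ccc1-n1cnnn1)[C@@H]1[C@@H]2C[C@@H]2CN1C(=O)[C@H](O)c1ccccc1`) carries phenyl in place of butyl on a saturated chain carbon bound to a carbonyl carbon and an oxygen on a saturated carbon. For the measured compounds named here, one measured step bears on this, read in reverse and on a core other than that of compound 2 (a 1.1-fold lower number from compound 1 to compound 3 (0.05 log units; within the scatter)), where propyl replaces phenyl. That step lies within the scatter, so no shift beyond the scatter is expected in this assay for compound 4 either. The estimated step is therefore small (a 1.3-fold lower number from compound 2 to compound 4 (0.12 log units; within the scatter)). For compound 4 the estimated value is 25 10^-6 cm/s with an expected range (from 12 10^-6 cm/s to 50 10^-6 cm/s).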

Compound 4, apparent permeability: 2.2 10^-6 cm/s
Compound 4: the middle estimate sits 11-fold (1.06 log units) above what was measured; the measured number lies below the stated range.
By their numbers in this assay, from the lowest: compound 4; then compounds 3 and 1 (each within the scatter of the next); then compound 2.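

In this assay, phenyl in place of butyl on a saturated chain carbon bound to a carbonyl carbon and an oxygen on a saturated carbon gives a large drop, a 15-fold lower number from compound 2 to compound 4 (1.18 log units; beyond the scatter). The earlier exchange, a 1.1-fold lower number from compound 1 to compound 3 (0.05 log units; within the scatter), at a different place and on a different core, stayed within the scatter, so its flat result does not carry over to this position. No measurement given here accounts for the size of this step.

The compounds shown leave open how benzyl, hexyl or an amine would read at this place on the core of compound 2. They also leave open whether phenyl here gives a similar drop on the core of compound 1.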